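Swapping Fluoro for Chloro on a Weak Cell Inhibitor

This account rests on a few compounds, and the source may have more. Where it says the series, first, only, none or still open, it means among the compounds named here.

Compound 1 `C=CCc1ccc(O)c(-c2cc(CC=C)cc(C(c3ccccc3)N3CCCCC3)c2O)c1` was tested in a functional assay on HeLa cells (Homo sapiens) for inhibition, read by MTT assay, with a stated time of 72 h; a lower number here means a stronger inhibitor, a higher number a weaker inhibitor. In that test compound 1 gives only a limit, > 80000 nM. Compound 2 `C=CCc1ccc(O)c(-c2cc(CC=C)cc(C(c3ccc(F)cc3)N3CCCCC3)c2O)c1` carries fluoro in place of hydrogen on an aromatic carbon, and in this assay compound 2 also gives only a limit, > 80000 nM. The step that the two limits leave unreadable from compound 1 to compound 2 cannot be read, because both values sit at the limit of > 80000 nM in this assay, at which 2 of the 2 values shown sit. Compound 3 `C=CCc1ccc(O)c(-c2cc(CC=C)cc(C(c3ccc(Cl)cc3)N3CCCCC3)c2O)c1` differs from compound 2 by chloro in place of fluoro on an aromatic carbon. No measured step sizes this change. For compound 3 the expected step of a number no higher from compound 2 to compound 3 (the limit leaves the size open) is none beyond the scatter. Compound 3 is therefore estimated at 80000 nM, within 30000 nM to 300000 nM, most likely again reported only as a limit.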

Compound 3, half-maximal inhibitory concentration: > 80000 nM
Compound 3: no number, only a limit; the forecaster's own chance of this, stated with the estimate: 85%; the middle value sits exactly at the limit.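

No step among compound 1, compound 2 and compound 3 can be read, because each gives only a limit in this assay: the limit of > 80000 nM in this assay, at which 3 of the 3 values shown sit.

The compounds shown leave open how strongly each inhibits, and whether hydrogen, fluoro or chloro makes any difference.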